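The source may report more compounds than this note shows. Statements on the series, on what has been measured and on what is new or still open speak of the compounds shown alone.

Three compounds share one core here: compound 1 (`COc1ccc(OC(=O)c2nc(C)c(C)nc2C)c(/C=C/C(=O)O)c1`), compound 2 (`Cc1nc(C)c(C(=O)Oc2ccc(Cl)cc2/C=C/C(=O)O)nc1C`) and the still unmeasured compound 3 (`CCOC(=O)/C=C/c1cc(Cl)ccc1OC(=O)c1nc(C)c(C)nc1C`). In a functional assay on EA.hy 926 cells (Homo sapiens) for cytotoxicity, read by MTT assay, with stated times of 24 h and 12 h (on this read-out higher numbers stand for an effect only at larger amounts of compound and lower numbers for an effect already at smaller amounts), compound 1 gives 48600 nM and compound 2 gives 95200 nM. Going by the values given here, these two values lie within the usual scatter of each other, so compound 2 cannot be separated from the only other compound measured so far.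

Compound 3 differs from compound 2 at the acid end of the molecule, where carboxy becomes ethoxycarbonyl: ethyl in place of hydrogen on an oxygen next to a carbonyl group. Among the compounds with values here, only one measured step is available, a 2.0-fold higher number from compound 1 to compound 2 (0.29 log units; within the scatter). It is a small step within the scatter, and it comes from a different change, chloro in place of methoxy on an aromatic carbon. Within the data shown here, no measured compound shows what happens when this acid becomes an ester, so the data give no direction for the change and the uncertainty is wide. The expected change in this assay is therefore none beyond the scatter, and the estimated step is a 1.6-fold lower number from compound 2 to compound 3 (0.20 log units; within the scatter). The estimate for compound 3 is 60000 nM, with an expected range from 15000 nM to 200000 nM.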

Compound 3, half-maximal effective concentration: 36100 nM
Compound 3: the middle estimate sits 1.7-fold (0.22 log units) above what was measured; low and high end bracket the measured number.
By their numbers in this assay, from the lowest: compounds 3, 1 and 2 (each within the scatter of the next, the first and the last beyond it).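

Going by these compounds alone, replacing the hydrogen of the acid with ethyl, so that carboxy becomes ethoxycarbonyl, produces the first step in this short series that lies beyond the scatter: in this assay there is a 2.6-fold lower number from compound 2 to compound 3 (0.42 log units; beyond the scatter), a modest change. Within the data shown here, the only earlier step, at a different place on the shared core, could not be told apart from repeat-measurement noise, so this pair gives the first sign that a single change can move the number in this assay. At this position, on an oxygen next to a carbonyl group, the ethyl ester shows its effect at smaller amounts of compound than the free acid does, although nothing given here explains this direction.

On these data alone, it remains open whether a methyl group or a longer chain such as butyl on this oxygen, or an amide in place of the ester, would move the number further or reverse it. Also open, as far as these compounds go, is whether the same ethyl change would give a similar step with methoxy in place of chloro on the aromatic carbon.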